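The source may hold more compounds than are shown below. What is called first, only, known or untested is meant among the compounds shown, and "the series" means these compounds.

In an assay for inhibition of Amine oxidase [flavin-containing] A (Bos taurus), read by fluorescence, with a stated time of 60 min (a lower number here means a stronger inhibitor, a higher number a weaker inhibitor), compound 2 `O=C(Cn1c(=O)c(Cc2ccccc2)nc2ccccc21)N/N=C/c1ccccc1` gives 3.1 nM, which is the lowest of the two numbers obtained so far. Its nearest neighbour is compound 1 `O=C(Cn1c(=O)c(Cc2ccccc2)nc2ccccc21)NNC(=O)c1ccc(Cl)cc1`, which in this assay gives 64 nM; the step of a 21-fold lower number from compound 1 to compound 2 (1.31 log units; beyond the scatter) is large and lies well beyond the scatter. Compound 3 `COc1ccc(/C=N/NC(=O)Cn2c(=O)c(Cc3ccccc3)nc3ccccc32)cc1` has not yet been measured in this assay. It differs from compound 2 in a single place: methoxy in place of hydrogen on an aromatic carbon. Among the measured compounds shown here, no measured step bears on this particular change. For the measured compounds named here, the only step seen so far concerns a different place, a whole group exchanged on an amide-type nitrogen, and it says nothing about a methoxy added to the aromatic ring. Going by the values given here, with no comparable step to draw on, the expectation is that the step of a 1.1-fold higher number from compound 2 to compound 3 (0.05 log units; within the scatter) stays within the usual scatter, with no clear direction either way. Compound 3 is therefore estimated to give about 3.5 nM in this assay, with a range running from 1 nM to 12 nM.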

Compound 3, half-maximal inhibitory concentration: 6.6 nM
Beside the measured number, compound 3's estimate is 1.9-fold (0.28 log units) below it, within the range that was stated.
By their numbers in this assay, from the lowest: compound 2; then compound 3; then compound 1.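

In this assay, among the compounds shown here, this is the first evidence on the far aromatic ring itself, since the earlier step concerned a whole group exchanged on an amide-type nitrogen, and methoxy in place of hydrogen, para to a large group, carries a modest cost, with a 2.1-fold higher number from compound 2 to compound 3 (0.33 log units; beyond the scatter). The position is therefore not indifferent to substitution, although the cost is small enough that the 4-methoxyphenyl compound stays far closer to compound 2 than to compound 1, with a 9.7-fold lower number from compound 1 to compound 3 (0.99 log units; beyond the scatter), so the exchange on the amide-type nitrogen still holds the larger effect among these three compounds. Nothing available explains why the methoxy group raises the number.

The compounds shown leave open whether this modest rise belongs to methoxy in particular or would appear with any group on this aromatic carbon, such as a fluorine, a hydroxyl or an amine. They also leave open whether a longer chain such as ethoxy or butoxy at the same place would raise the number further or leave it where methoxy puts it.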